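Swapping bromo for hydrogen on compound 2

A few compounds are considered here, and "the series" means these few. Any claim that something is new, unique, unknown or untested is made for them only; others in the source may bear on it.

In a functional assay on NALM-6 cells (Homo sapiens) for cytotoxicity, read by luminescence and CellTiter-Glo, with a stated time of 3 days (on this read-out higher numbers stand for weaker inhibition and lower numbers for stronger inhibition), compound 2 `N#Cc1ccc(NC(=O)c2cc(Br)c3cccnc3c2O)cc1` gives 210 nM. Compound 1 `O=C(Nc1cc(F)cc(F)c1)c1ccc2cccnc2c1O` gives 310 nM, within the scatter of compound 2. Compound 3 `O=C(Nc1ccc(Cl)cc1Cl)c1ccc2cccnc2c1O` gives 450 nM, a higher number than compound 2 by more than the scatter, so it points to weaker inhibition. Compound 4 `N#Cc1ccc(NC(=O)c2ccc3cccnc3c2O)cc1` has not been measured yet and differs from compound 2 at one place: hydrogen in place of bromo on an aromatic carbon. Hydrogen stands in place of bromo on an aromatic carbon. Going by the values given here, no measured pair shows this change alone. Compound 1 and compound 3 also lack bromo, but they differ elsewhere too. A small rise, not clearly beyond the scatter, is therefore expected in this assay, and the estimated step is a 1.4-fold higher number from compound 2 to compound 4 (0.15 log units; within the scatter). For compound 4 the expected value is 300 nM, within an estimated range of 120 nM to 700 nM.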

Compound 4, half-maximal inhibitory concentration: 130 nM
The estimate for compound 4 lay 2.3-fold (0.36 log units) above the measured number; low and high end bracket the measured number.
By their numbers in this assay, from the lowest: compounds 4, 2, 1 and 3 (each within the scatter of the next, the first and the last beyond it).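

Going by these compounds alone, the step in this assay is a 1.6-fold lower number from compound 2 to compound 4 (0.21 log units; within the scatter) and gives the first reading of this change on its own. At this place, para to a hydroxy group, bromo can give way to hydrogen with no shift beyond the usual scatter, so the bromo is not needed for a number of this size. Nothing measured here explains why the two compounds read alike.

On these data alone, whether an amine, a carboxylic acid or a methoxy group at this place would give a similar number remains open. So does whether adding bromo to compound 1 or compound 3 would leave their numbers similarly unmoved.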